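This account rests on a few compounds, and the source may have more. Where it says the series, first, only, none or still open, it means among the compounds named here.

In an ADME assay on HCT-116 cells (Homo sapiens) for cytotoxicity, read by CellTiter-Glo, with a stated time of 72 h (on this read-out lower numbers stand for stronger inhibition and higher numbers for weaker inhibition), compound 2 (`CC1CCN(C2CCN(S(=O)(=O)c3cccc(N)c3)CC2)CC1`) gives > 5000 nM as a limit and not a number. Compound 1 (`CC1CCN(C2CCN(S(=O)(=O)c3cccc(C(F)(F)F)c3)CC2)CC1`) gives > 5000 nM as a limit too. Among the compounds with values here, the evidence stands at the limit of > 5000 nM in this assay, at which 2 of the 2 values shown sit, and the one measured step is a step that the two limits leave unreadable from compound 1 to compound 2 so no size carries forward. Compound 3 (`COc1ccccc1-c1cccc(S(=O)(=O)N2CCC(N3CCC(C)CC3)CC2)c1`) has 2-methoxyphenyl in place of amino on an aromatic carbon, counted as 2-methoxyphenyl in place of amino on an aromatic carbon against compound 2. No direction follows for this assay and the expected change is a step that the limit leaves unreadable from compound 2 to compound 3 with a reported limit the likeliest outcome. Compound 3 is estimated at 6000 nM with 2500 nM to 15000 nM as the expected range.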

Compound 3, half-maximal inhibitory concentration: > 5000 nM
Compound 3 gave a limit, no number; the forecaster's own chance of this, stated with the estimate: 70%; the middle value lies beyond the limit too.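

No step can be read among compound 1, compound 2 and compound 3 in this assay, because each value is a limit and not a number: the limit of > 5000 nM in this assay, at which 3 of the 3 values shown sit.

Still open, going by these compounds, is whether these three compounds differ at all in this assay, and by how much.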